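The compounds below may be only part of what the source reports. "The series", "measured", "known", "first", "only" and "open" are said of these compounds alone.

Compound 1 `Cn1cc(-c2ccc(C(F)(F)F)cc2)c2cc(F)c(C(=O)NS(=O)(=O)C3CC3)cc21` at 100% 
Compound 2 `Cn1cc(-c2ccc(C(F)(F)F)cc2)c2ccc(C(=O)NS(=O)(=O)C3CC3)cc21` at 87% 

In an ADME assay on microsomes from liver (Homo sapiens) for metabolic stability, with a stated time of 10 min, tested at 0.5 uM (a higher number here means that more of the compound is left, a lower number that less of the compound is left), compound 1 at 100% holds the higher of the two numbers. The other number is reached by a number 13 percentage points lower from compound 1 to compound 2 (beyond the scatter) and that step, hydrogen in place of fluoro on an aromatic carbon, lies beyond the scatter but is modest. Compound 3 `Cn1cc(-c2ccc(C(F)(F)F)cc2)c2cc(F)c(C(=O)NS(C)(=O)=O)cc21` keeps the fluoro and the core of compound 1 and differs elsewhere: methyl in place of cyclopropyl on a sulfonyl sulfur. Within the data shown here, no measured step touches the sulfonyl sulfur, so the one step bears only indirectly, as a guide to how large a single change can be. A modest step or a smaller one is expected, downward if anything, since compound 1 at 100% leaves little room upward. The expected change is a number 8 percentage points lower from compound 1 to compound 3 (within the scatter) and may well stay within the scatter. For compound 3 the estimate is 92% with an expected range from 78% to 100% in this measurement.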

Compound 3, percent of the compound remaining: 97%
The estimate for compound 3 lay 5 percentage points below the measured number; measured number inside the range.
By their numbers in this assay, from the lowest: compounds 2, 3 and 1 (each within the scatter of the next, the first and the last beyond it).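

At the sulfonyl sulfur, the measured change from cyclopropyl to methyl gives a number 3 percentage points lower from compound 1 to compound 3 (within the scatter) in this assay, so the three-membered ring is not needed to keep this number when the fluoro and the core of compound 1 stay in place. This is the first change shown at this position, and unlike the step at the aromatic carbon, a number 13 percentage points lower from compound 1 to compound 2 (beyond the scatter), it does not lie beyond the scatter. No supporting measurement is available to explain this result.

As far as these compounds go, whether a longer chain, a phenyl ring or an amine on the sulfonyl sulfur would leave the number in this assay equally undisturbed remains open. So does whether methyl in place of cyclopropyl would give a similar step with hydrogen in place of the fluoro.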